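Amide chain variation on a shared core: fluorophenyl step

The compounds below may be only part of what the source reports. "The series", "measured", "known", "first", "only" and "open" are said of these compounds alone.

The series shares the core of compound 1 `CN(C(=O)CCCc1ccccc1)c1nc2ccccc2c(=O)s1` and varies the amide-type nitrogen and the chain on the carbonyl. In an assay on CHO cells for displacement of a labelled ligand from adenosine receptor A3 (Homo sapiens), read by scintillation counting, with a stated time of 60 min (a lower number here means a stronger inhibitor, a higher number a weaker inhibitor), compound 1 gives > 1000 nM, which is a limit of the assay and not a number. Compound 2 `O=C(CCCc1ccccc1)Nc1nc2ccccc2c(=O)s1` gives > 1000 nM in this assay, again a limit. Compound 3 `O=C(CCCc1ccccc1)Nc1nc2ccc(Br)cc2c(=O)s1` gives > 1000 nM in this assay, also a limit. Hence a step that the two limits leave unreadable from compound 1 to compound 2 and a step that the two limits leave unreadable from compound 2 to compound 3 cannot be read, since (the limit of > 1000 nM in this assay, at which 3 of the 3 values shown sit). Compound 2 thus stands only at a limit in this assay, with no number to anchor it.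

Compound 4 `O=C(CCc1ccccc1F)Nc1nc2ccccc2c(=O)s1` differs from compound 2 by 2-fluorophenyl in place of benzyl on a saturated chain carbon, two bonds along the chain from a carbonyl carbon. Among the compounds with values here, no measured step touches this part of the chain, and the two steps that are known are both unreadable, so no direction can be drawn for this assay. The expectation for compound 4 is then 3000 nM in this assay, within 800 nM to 20000 nM. The step that this estimate means is a step that the limit leaves unreadable from compound 2 to compound 4, and it is expected that this assay may again report only a limit.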

Compound 4, inhibition constant: >= 1000 nM
Compound 4 ended at the assay's limit; the forecaster's own chance of this, stated with the estimate: 70%; the middle value is on the limit's open side.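

Compound 4 gives >= 1000 nM in this assay, which is a limit and not a number. Within the data shown here, no step from compound 2 to compound 4 can be read, as both stand only at limits. The compounds shown leave open which change to the amide chain or shared core, if any, would give a measurable value.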